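Moving the amine one carbon out along the chain

The source may report more compounds than this note shows. Statements on the series, on what has been measured and on what is new or still open speak of the compounds shown alone.

Compound 1, `N[C@H](CN(C(=O)[C@@H]1C[C@H]1c1ccccc1)c1ccc(-c2ccccc2)cc1)C1CCCCC1`, gives 0.66 nM in a functional assay for agonist activity at G protein-coupled receptor 88 (Homo sapiens), read by HTRF and cAMP accumulation; a higher number here means that more compound is needed for the effect, a lower number that less compound is needed.
Compound 2, `CC(C)(N)CN(C(=O)[C@@H]1C[C@H]1c1ccccc1)c1ccc(-c2ccccc2)cc1`, gives 1.4 nM in this assay.
Compound 3, `CC(C)(C)[C@H](N)CN(C(=O)[C@@H]1C[C@H]1c1ccccc1)c1ccc(-c2ccccc2)cc1`, gives 11 nM in this assay.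

Compound 3 has the highest number of the three: a 17-fold higher number from compound 1 to compound 3 (1.22 log units; beyond the scatter) and a 7.9-fold higher number from compound 2 to compound 3 (0.90 log units; beyond the scatter). Compound 4, `CCC(C)CNCCN(C(=O)[C@@H]1C[C@H]1c1ccccc1)c1ccc(-c2ccccc2)cc1`, differs from compound 3 by ((2-methylbutyl)amino)methyl in place of 1-amino-2,2-dimethylpropyl on a saturated chain carbon bound to an amide-type nitrogen; the stereocentre is gone. The measured steps only show that larger branching on the amine-bearing carbon raised the number, as in a 17-fold higher number from compound 1 to compound 3 (1.22 log units; beyond the scatter); none moves the amine itself or alkylates it, so the direction is uncertain. Since compound 3 stands at the weak end, compound 4 is expected to sit somewhat lower, a step of a 2.8-fold lower number from compound 3 to compound 4 (0.44 log units; beyond the scatter), giving an estimate of 4 nM with a range from 0.8 nM to 20 nM.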

Compound 4, half-maximal effective concentration: 4.7 nM
Compound 4: middle estimate off by 1.2-fold (0.07 log units), on the low side; the measured number falls inside the stated range.
By their numbers in this assay, from the lowest: compound 1; then compound 2; then compound 4; then compound 3.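

With the 2-((2-methylbutyl)amino)ethyl chain, which has no defined stereocentre, the record shows a 2.3-fold lower number from compound 3 to compound 4 (0.37 log units; beyond the scatter) in this assay and so the amine need not stand on a branched carbon for the number to fall. The same chain still loses ground to the other two, with a 3.4-fold higher number from compound 2 to compound 4 (0.53 log units; beyond the scatter) and a 7.1-fold higher number from compound 1 to compound 4 (0.85 log units; beyond the scatter) on the other side of it. Nothing measured here accounts for these steps.

Open, from the compounds shown here alone, is how much of this belongs to the 2-methylbutyl group itself. A plain ethyl or a cyclohexylmethyl on that amine nitrogen would separate the substituent from the shift of the amine along the chain.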